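A few compounds are considered here, and "the series" means these few. Any claim that something is new, unique, unknown or untested is made for them only; others in the source may bear on it.

Of the compounds shown here, three built on one shared core have been measured in an assay for inhibition of NADPH oxidase 4 (Homo sapiens), read by chemiluminescence; on this read-out higher numbers stand for weaker inhibition and lower numbers for stronger inhibition. Compound 1 `CCc1ccc(N2C(=O)/C(=C/c3ccc(O)cc3O)N(C)C2=S)cc1` gives 2390 nM. Compound 2 `CCc1ccc(N2C(=O)/C(=C/c3ccc(N(C)C)cc3)N(C)C2=S)cc1` gives 2630 nM. Compound 3 `CN1C(=S)N(c2ccc3c(c2)CCC3)C(=O)/C1=C/c1ccc(O)cc1O` gives 6830 nM, the highest of the three numbers; its gaps to compound 2 and to compound 1 both lie beyond the usual scatter, so compound 3 is the weakest inhibitor among them.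

Compound 4 `CN1C(=S)N(c2ccc3c(c2)CCC3)C(=O)/C1=C/c1cccc(O)c1O` has not yet been measured. It differs from compound 3 in one place: 2,3-dihydroxyphenyl in place of 2,4-dihydroxyphenyl on a double-bonded chain carbon bound to a double-bonded ring carbon. Within the data shown here, no pair of measured compounds differs only in this way, so the size of the step cannot be read from the data. All three measured compounds are weak inhibitors, and nothing in the data points to a large change. The expectation is a small step toward a higher number, of a size that may not exceed the usual scatter. The expected step is a 1.2-fold higher number from compound 3 to compound 4 (0.07 log units; within the scatter). Compound 4 is therefore expected to give 8000 nM, with a plausible range from 3000 nM to 20000 nM.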

Compound 4, inhibition constant: 2360 nM
Estimate against measurement, compound 4: 3.4-fold (0.53 log units) above, outside the stated range (below it).
By their numbers in this assay, from the lowest: compounds 4, 1 and 2 (each within the scatter of the next); then compound 3.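

In this assay, exchanging 2,4-dihydroxyphenyl for 2,3-dihydroxyphenyl on a double-bonded chain carbon bound to a double-bonded ring carbon gives a 2.9-fold lower number from compound 3 to compound 4 (0.46 log units; beyond the scatter). The atoms and the counts of hydrogen-bond donors and acceptors stay the same, so at this place the arrangement of the two hydroxyl groups alone is enough to move the number beyond the usual scatter, though the step is only modest. Nothing available explains why this arrangement gives the lower number.

Among these compounds, whether the same exchange would give a similar step on the core of compound 1 remains open, as this single pair is the only evidence for it. Also open, from the compounds shown here alone, is how this place would respond to a phenyl ring carrying a methoxy group or a carboxylic acid instead of the two hydroxyl groups.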